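Shortening the side chain in two uridine series

This account rests on a few compounds, and the source may have more. Where it says the series, first, only, none or still open, it means among the compounds named here.

Compound 1 `CCCCCCCCc1cn([C@H]2C[C@@H]3OP(=O)(O)OC[C@H]3O2)c(=O)[nH]c1=O` carries a long alkyl chain on a cyclic phosphate core. In a functional assay on L1210 cells (Mus musculus) (on this read-out lower numbers stand for stronger inhibition and higher numbers for weaker inhibition), compound 1 gives 193 ug/mL. Compound 3 `CCCCCCc1cn([C@H]2C[C@@H]3OP(=O)(O)OC[C@H]3O2)c(=O)[nH]c1=O` differs from it by hydrogen in place of ethyl on a saturated chain carbon, six bonds along the chain from an aromatic carbon. For compound 3 the read-out is a limit of the assay, > 500 ug/mL, so only a bound is known. The step of an at least 2.5-fold higher number from compound 1 to compound 3 (0.41 log units; beyond the scatter) therefore rests on (the limit of > 500 ug/mL in this assay, at which 1 of the 3 values shown sits).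

Compound 2 `CCCCCCc1cn([C@H]2C[C@H](O)[C@@H](CO)O2)c(=O)[nH]c1=O` has a free sugar instead; the difference between the two cores is not broken down here. In this assay compound 2 gives 195 ug/mL. Compound 4 `CCCCc1cn([C@H]2C[C@H](O)[C@@H](CO)O2)c(=O)[nH]c1=O`, not yet measured, differs from compound 2 by hydrogen in place of ethyl on a saturated chain carbon, four bonds along the chain from an aromatic carbon. Going by the values given here, this is the same kind of change as the one from compound 1 to compound 3, though the place differs: there the chain carbon sat six bonds along the chain from an aromatic carbon, here it sits four bonds along.

Because the earlier step gave an at least 2.5-fold higher number from compound 1 to compound 3 (0.41 log units; beyond the scatter), a step of a 2.6-fold higher number from compound 2 to compound 4 (0.41 log units; beyond the scatter) is expected here. For compound 4 the estimate is 500 ug/mL, between 250 ug/mL and 1000 ug/mL.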

Compound 4, concentration for 50% inhibition: > 500 ug/mL
Compound 4 was reported as a limit; the forecaster's own chance of this, stated with the estimate: 55%; the middle value sits exactly at the limit.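

On the free sugar core, hydrogen in place of ethyl gives, in this assay, an at least 2.5-fold higher number from compound 2 to compound 4 (0.40 log units; beyond the scatter). The change thus moves the read-out towards weaker inhibition on both cores, so in these two pairs its direction carries over from one core to the other: the same change on two cores in this assay, an at least 2.5-fold higher number (0.41 log units; beyond the scatter) from compound 1 to compound 3 and an at least 2.5-fold higher number (0.40 log units; beyond the scatter) from compound 2 to compound 4; the limit leaves it open whether they differ. For compound 4 the read-out > 500 ug/mL is a limit of the assay, so the carry-over is shown in direction only and not in size: the limit of > 500 ug/mL in this assay, at which 2 of the 4 values shown sit.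

The two pairs also differ in where the change sits, six bonds along the chain from an aromatic carbon in one and four bonds along in the other, and the compounds shown cannot separate that difference from the change of core. Also open, on these data alone, is how either core would behave with a longer chain than that of compound 1, or with an amine or a carboxylic acid in place of the alkyl chain.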